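Chalcone amide series: cytotoxicity notes before compound 3

The source may hold more compounds than are shown below. What is called first, only, known or untested is meant among the compounds shown, and "the series" means these compounds.

Measured so far:
compound 1 `COC(=O)c1cc(-c2cccc(NC(=O)c3ccc(/C=C/C(=O)c4ccccc4Br)cc3)c2)on1` — > 40 ug/mL
compound 2 `COC(=O)c1cc(-c2cccc(NC(=O)c3ccc(/C=C/C(=O)c4ccc(Br)cc4)cc3)c2)on1` — > 20 ug/mL

In an ADME assay on Vero cells (Chlorocebus sabaeus) for cytotoxicity, read by MTT assay, with a stated time of 72 h (on this read-out lower numbers stand for higher toxicity in this test and higher numbers for lower toxicity in this test), compound 1 gives > 40 ug/mL, which is a limit of the assay and not a number. In this assay compound 2 gives > 20 ug/mL, again a limit rather than a number. The step that the two limits leave unreadable from compound 1 to compound 2 therefore cannot be read, since both of its ends sit at a limit, as the limit of > 20 ug/mL in this assay, at which 1 of the 2 values shown sits, and the limit of > 40 ug/mL in this assay, at which 1 of the 2 values shown sits, show. Among the measured compounds shown here, compound 2 thus stands at a limit, and the one further value is also a limit, so no ordering between compound 1 and compound 2 is visible.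

Compound 3 `COC(=O)c1cc(-c2cccc(NC(=O)c3ccc(/C=C/C(=O)c4ccc(Cl)cc4)cc3)c2)on1` differs from compound 2 by chloro in place of bromo on an aromatic carbon. No measured step bears on this change with a readable size; the only step shown, from compound 1 to compound 2, is unreadable. With that, the change is expected to give no step beyond the scatter, and the expected step that the limit leaves unreadable from compound 2 to compound 3 is written as such. Compound 3 is expected to sit at 40 ug/mL in this assay, with a range from 20 ug/mL to 100 ug/mL, most likely reported again as a limit.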

Compound 3, half-maximal cytotoxic concentration: > 50 ug/mL
Compound 3 gave a limit, no number; the forecaster's own chance of this, stated with the estimate: 80%; at least 1.2-fold (0.09 log units) between middle value and limit.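

In this assay compound 3 gives > 50 ug/mL, a limit of the assay and not a number. Among the compounds shown here, with compound 1 and compound 2 also at limits, no step from compound 2 to compound 3 or from compound 1 to compound 3 can be read. The compounds shown leave open whether bromo and chloro differ at all in this assay, and at what concentration any of the three compounds reaches its half-maximal cytotoxic effect.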